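Adding a Phenyl to the Methyl Ester of Compound 2

The source may report more compounds than this note shows. Statements on the series, on what has been measured and on what is new or still open speak of the compounds shown alone.

- Compound 1 `C=C1CC[C@@H]2[C@](C)(CCC[C@]2(C)C(=O)O)[C@H]1CCC1=CCc2c(OC(C)=O)ccc(OC(C)=O)c2C1` gives 2500 nM
- Compound 2 `C=C1CC[C@@H]2[C@](C)(CCC[C@]2(C)C(=O)OC)[C@H]1CCc1ccc2c(OCc3ccccc3)ccc(OCc3ccccc3)c2c1` gives > 5000 nM

In a functional assay on A549 cells (Homo sapiens) for cytotoxicity, read by sulforhodamine B assay, with a stated time of 72 h (on this read-out lower numbers stand for stronger inhibition of growth and higher numbers for weaker inhibition of growth), compound 1 gives 2500 nM. Compound 2 stands at > 5000 nM, which is a limit and not a number. Compound 3 `C=C1CC[C@@H]2[C@](C)(CCC[C@]2(C)C(=O)OCc2ccccc2)[C@H]1CCc1ccc2c(OCc3ccccc3)ccc(OCc3ccccc3)c2c1` differs from compound 2 by phenyl in place of hydrogen on a saturated chain carbon bound to an oxygen next to a carbonyl group, with phenyl in place of hydrogen on a saturated chain carbon bound to an oxygen next to a carbonyl group, turning methoxycarbonyl into benzyloxycarbonyl. Among the measured compounds shown here, no measured step bears on this change, so only a small shift towards weaker growth inhibition is expected, and the estimated step runs a step that the limit leaves unreadable from compound 2 to compound 3. Compound 3 is expected at 7000 nM, with an estimated range from 3500 nM to 15000 nM.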

Compound 3, concentration for 50% growth inhibition: 6500 nM
Beside the measured number, compound 3's estimate is 1.1-fold (0.03 log units) above it; measured number inside the range.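

Among the compounds shown here, the value of compound 2 is a limit and not a number, so no step from compound 2 to compound 3 can be read. The compounds shown leave open how far turning methoxycarbonyl into benzyloxycarbonyl shifts the result in this assay.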